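Chloro for trifluoromethyl: next step in the series

The source may hold more compounds than are shown below. What is called first, only, known or untested is meant among the compounds shown, and "the series" means these compounds.

Measured so far:
compound 1 `CCOC(=O)c1sc(-c2cccc(NC(=O)c3ccc(C(F)(F)F)cc3)c2)nc1Nc1ccc(N2CCN(C)CC2)cc1` — 33%
compound 2 `CCOC(=O)c1sc(-c2cccc(NC(=O)c3ccc(F)cc3)c2)nc1Nc1ccc(N2CCN(C)CC2)cc1` — 16.8%

In a functional assay on Raji cells (Homo sapiens) for antiproliferative activity, read by CCK-8 assay, with a stated time of 72 h, tested at 40 uM (a higher number here means more inhibition at the concentration tested (going by the name of the read-out), a lower number less inhibition), compound 1 gives 33%, the highest of the two numbers available; compound 2 gives 16.8%. Among the measured compounds shown here, the only measured step, a number 16.2 percentage points lower from compound 1 to compound 2 (beyond the scatter), is also the only one that bears on the next compound, as it changes the same aromatic carbon of the shared core of compound 1.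

Compound 3 `CCOC(=O)c1sc(-c2cccc(NC(=O)c3ccc(Cl)cc3)c2)nc1Nc1ccc(N2CCN(C)CC2)cc1` has not yet been measured. It differs from compound 1 by chloro in place of trifluoromethyl on an aromatic carbon. The step from compound 1 to compound 2 was modest and beyond the scatter; chloro is not fluoro, and nothing measured shows how chloro behaves here, so a smaller downward step, or none beyond the scatter, is expected in this assay. The expected step is a number 7 percentage points lower from compound 1 to compound 3 (within the scatter). Compound 3 is estimated at 26%, with a range from 14% to 38%.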

Compound 3, a percentage reported as inhibition, at one concentration (the size of the read-out at that concentration, not a potency): 24.3%
Estimate against measurement, compound 3: 1.7 percentage points above; the range from low to high includes it.
By their numbers in this assay, from the lowest: compounds 2, 3 and 1 (each within the scatter of the next, the first and the last beyond it).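

In this assay, the position para to a large group now carries a third substituent, and chloro in place of trifluoromethyl gives a number 8.7 percentage points lower from compound 1 to compound 3 (within the scatter), while chloro in place of fluoro gives a number 7.5 percentage points higher from compound 2 to compound 3 (within the scatter). Compound 3 therefore cannot be separated from either neighbour, so the only resolved difference at this aromatic carbon remains a number 16.2 percentage points lower from compound 1 to compound 2 (beyond the scatter), and chloro adds an intermediate reading that fits within the scatter of both. No measured evidence accounts for these readings at this position.

The compounds shown leave open how a methoxy group, an amine or a carboxylic acid on this aromatic carbon would read in this assay. They also leave open whether any replacement here could give a reading clearly beyond that of compound 1.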